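Removing a Methoxy Group from Compound 3

The source may report more compounds than this note shows. Statements on the series, on what has been measured and on what is new or still open speak of the compounds shown alone.

Of the compounds shown here, three from this series have been measured in an ADME assay on RAW264.7 cells (Mus musculus) for cytotoxicity, read by MTT assay, with a stated time of 24 h, tested at 5 ug/mL; a lower number here means a stronger effect, a higher number a weaker effect of the compound at the concentration tested. Compound 1 `COc1cc(C(=O)CCc2cccc(OC)c2OC)ccc1O` gives 91.1% in this assay. Compound 2 `COc1ccc(C(=O)CCc2ccc(OC)cc2OC)c(O)c1` gives 87.4%, and compound 3 `COc1ccc(C(=O)CCc2ccc(OC)c(OC)c2)c(O)c1` gives 75.2%. Among these three numbers, compound 3 stands lowest: its nearest neighbour is compound 2, whose number lies beyond the scatter above it, and the furthest is compound 1, also beyond the scatter above it. Among the compounds with values here, no pair of these three compounds differs in only one place, so no single step between measured compounds can be drawn from them.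

Compound 4 `COc1ccc(CCC(=O)c2ccc(OC)cc2O)cc1` has not yet been measured in this assay. It differs from compound 3 by hydrogen in place of methoxy on an aromatic carbon, a hydrogen in place of methoxy on an aromatic carbon, ortho to the remaining methoxy group and meta to the large group.

Within the data shown here, since the three measured compounds give no step of one change, the size of the step from compound 3 to compound 4 is uncertain. Among the measured compounds shown here, a small rise is expected, a number 4.8 percentage points higher from compound 3 to compound 4 (within the scatter), as a modest move from compound 3 back toward the numbers of compound 1 and compound 2, with no expectation of a step clearly beyond the scatter. Compound 4 is therefore estimated at 80% in this assay, within a range from 68% to 94%.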

Compound 4, a percentage reported as activity, at one concentration (the size of the read-out at that concentration, not a potency): 92.3%
Beside the measured number, compound 4's estimate is 12.3 percentage points below it; the measured number falls inside the stated range.
By their numbers in this assay, from the lowest: compound 3; then compounds 2, 1 and 4 (each within the scatter of the next).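

In this assay, within the data shown here, replacing the methoxy group ortho to a methoxy group and meta to a large group with hydrogen gives the first single change that can be read at this position: a number 17.1 percentage points higher from compound 3 to compound 4 (beyond the scatter). The stronger effect of compound 3 at the concentration tested therefore depends on this methoxy group, since the step lies beyond the usual scatter. The same exchange of methoxy for hydrogen at a different aromatic carbon gives a number 4.9 percentage points higher from compound 2 to compound 4 (within the scatter), so in these two steps the result depends on which methoxy group leaves, and the data offer no measured property that accounts for the contrast.

Going by these compounds, only hydrogen and methoxy have been compared at this position, so it remains open whether the number in this assay would follow an ethoxy group, a hydroxyl group, a fluorine atom or an amine placed there. The two steps also leave open whether the effect seen for compound 3 requires both methoxy groups together or this one alone, in any compound with a different core.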